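This account rests on a few compounds, and the source may have more. Where it says the series, first, only, none or still open, it means among the compounds named here.

Measured compounds in an assay on Sf9 cells for inhibition of protein deacetylase HDAC6 (Homo sapiens), read by fluorescence, with a stated time of 40 min, tested at 100 nM; a lower number here means less inhibition, a higher number more inhibition at the concentration tested (going by the name of the read-out):
Compound 1 `COc1ccc(-n2nc(-c3ccccc3)nc2CNc2ccc(C(=O)NO)cc2)cc1` gives 63.4%.
Compound 2 `Cc1ccccc1-c1nc(CNc2ccc(C(=O)NO)cc2)n(-c2ccccc2)n1` gives 53.2%.
Compound 3 `CC(C)c1ccc(-c2nc(CNc3ccc(C(=O)NO)cc3)n(-c3ccccc3)n2)cc1` gives 27.6%.

Compound 1 stands highest of the three, beyond the scatter above both compound 2 and compound 3. Compound 4 `Cc1ccc(-n2nc(-c3ccccc3)nc2CNc2ccc(C(=O)NO)cc2)cc1C` keeps the shared core and changes one group: 3,4-dimethylphenyl in place of 4-methoxyphenyl on an aromatic nitrogen. For the measured compounds named here, the single measured step, a number 25.6 percentage points lower from compound 2 to compound 3 (beyond the scatter), concerns the aryl on an aromatic carbon, not the aryl on the ring nitrogen, so it does not bear directly on this change; it shows only that a larger aryl group there lowered inhibition. Going by the values given here, with no step at the ring nitrogen to lean on, a small fall or no change beyond the scatter is expected. Compound 4 is therefore estimated at 55%, between 35% and 72%, an expected step of a number 8.4 percentage points lower from compound 1 to compound 4 (within the scatter).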

Compound 4, a percentage reported as inhibition, at one concentration (the size of the read-out at that concentration, not a potency): 53%
The estimate for compound 4 lay 2 percentage points above the measured number; the measured number falls inside the stated range.
By their numbers in this assay, from the lowest: compound 3; then compounds 4 and 2 (each within the scatter of the next); then compound 1.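

In this assay, for the compounds shown here, the aryl group on the aromatic nitrogen proves to matter, which the earlier compounds could not show: the step is a number 10.4 percentage points lower from compound 1 to compound 4 (beyond the scatter). The two groups have the same count of heavy atoms, and the entering 3,4-dimethylphenyl has carbon in place of the oxygen and no hydrogen-bond acceptor, so the read-out changes without any change in heavy-atom count. Nothing measured here explains the difference.

A single step cannot separate the loss of the methoxy group from the gain of two methyl groups. As far as these compounds go, how a 4-aminophenyl, a 4-fluorophenyl or a cyclohexyl group would read at this position remains open.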